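From Cyclohexyl to Thiazolyl on the Amide Nitrogen

A few compounds are considered here, and "the series" means these few. Any claim that something is new, unique, unknown or untested is made for them only; others in the source may bear on it.

Of the compounds shown here, three that share one core have been tested in an ADME assay on MDCK cells (Canis lupus familiaris) for cytotoxicity, read by cytopathic effect, with a stated time of 48 h; a lower number here means that less compound is tolerated, a higher number that more compound is tolerated. Compound 1 `CCC(=O)Nc1cc(C(=O)Nc2ccc(C)cc2)ccc1OC` gives 162 uM in this assay, compound 2 `CCC(=O)Nc1cc(C(=O)Nc2ccc(Br)cc2)ccc1OC` gives 90.4 uM, and compound 3 `CCC(=O)Nc1cc(C(=O)NC2CCCCC2)ccc1OC` gives 510 uM. Among these, compound 3 stands highest, with compound 1 as its nearest neighbour and compound 2 as its furthest. The step of a 1.8-fold lower number from compound 1 to compound 2 (0.25 log units; within the scatter) is small. In contrast, the steps of a 3.1-fold higher number from compound 1 to compound 3 (0.50 log units; beyond the scatter) and a 5.6-fold higher number from compound 2 to compound 3 (0.75 log units; beyond the scatter) both lie beyond the scatter and point the same way, toward a higher number when cyclohexyl replaces 4-methylphenyl or 4-bromophenyl on the amide nitrogen.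

Compound 4 `CCC(=O)Nc1cc(C(=O)Nc2nccs2)ccc1OC` has not yet been measured. It differs from compound 3 by 1,3-thiazol-2-yl in place of cyclohexyl on an amide-type nitrogen. This change runs in the opposite sense to the two modest steps just named: a five-membered aromatic ring with 2 hetero atoms enters where the six-membered non-aromatic ring of carbon only leaves. Those two measured steps bear on the question directly, but neither involves a ring of this kind, so the size of the reversal is uncertain. A modest step toward a lower number is expected, a 2.6-fold lower number from compound 3 to compound 4 (0.41 log units; beyond the scatter). Compound 4 is therefore estimated at 200 uM, with a range from 80 uM to 500 uM.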

Compound 4, half-maximal toxic concentration: > 655 uM
Compound 4: no number, only a limit; the forecaster's own chance of this, stated with the estimate: 10%; middle value at least 3.2-fold (0.51 log units) from the limit.
By their numbers in this assay, from the lowest: compounds 2 and 1 (each within the scatter of the next); then compound 3. At a limit, above all of these: compound 4.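

In this assay compound 4 gives > 655 uM, which is a limit of the assay and not a number: the limit of > 655 uM in this assay, at which 1 of the 4 values shown sits. With an at least 1.2-fold higher number from compound 3 to compound 4 (0.10 log units; that floor lies within the scatter) the 1,3-thiazol-2-yl group shows no sign of the reversal that its aromatic ring might have suggested, although this floor alone cannot place compound 4 clearly above compound 3. The steps of an at least 4.0-fold higher number from compound 1 to compound 4 (0.60 log units; beyond the scatter) and an at least 7.2-fold higher number from compound 2 to compound 4 (0.86 log units; beyond the scatter) show that an aromatic ring on the amide-type nitrogen does not always go with the lower numbers, since compound 1 and compound 2 fit that reading and compound 4 goes against it.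

As far as these compounds go, how far the true number of compound 4 lies past its limit stays open, and with it the real size of all three steps. Also open is whether a pyridin-2-yl or 1,3-oxazol-2-yl ring on the same nitrogen would follow 1,3-thiazol-2-yl or the 4-methylphenyl and 4-bromophenyl groups, while the compounds shown keep the propanamide and methoxy groups of the shared core unchanged.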